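Three inactive analogues and a dichlorophenyl newcomer

A few compounds are considered here, and "the series" means these few. Any claim that something is new, unique, unknown or untested is made for them only; others in the source may bear on it.

Compound 3 `Cc1ccc(C)c(-n2nncc2CN2C(=O)C3(C(C#N)=C(N)Oc4c3c3nc5ccccc5nc3c3ccccc43)c3ccccc32)c1` carries a 2,5-dimethylphenyl group on an aromatic nitrogen of its triazole. In an ADME assay on HUVEC cells (Homo sapiens) for antiproliferative activity, read by MTT assay, with a stated time of 48 h (a lower number here means a stronger inhibitor, a higher number a weaker inhibitor), compound 3 returns only a limit of the assay, > 50000 nM. Its two neighbours in the series share the same fate. Compound 1 `Cc1ccccc1-n1nncc1CN1C(=O)C2(C(C#N)=C(N)Oc3c2c2nc4ccccc4nc2c2ccccc32)c2ccccc21` gives in this assay only a limit, > 50000 nM. Compound 2 `N#CC1=C(N)Oc2c(c3nc4ccccc4nc3c3ccccc23)C12C(=O)N(Cc1cnnn1-c1ccc(Br)cc1)c1ccccc12` likewise gives only a limit, > 50000 nM. Among the compounds with values here, the steps among them, a step that the two limits leave unreadable from compound 1 to compound 2, a step that the two limits leave unreadable from compound 1 to compound 3 and a step that the two limits leave unreadable from compound 2 to compound 3, therefore cannot be sized; all that can be said is captured in the limit of > 50000 nM in this assay, at which 3 of the 3 values shown sit, where every value so far sits.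

Compound 4 `N#CC1=C(N)Oc2c(c3nc4ccccc4nc3c3ccccc23)C12C(=O)N(Cc1cnnn1-c1ccc(Cl)c(Cl)c1)c1ccccc12` differs from compound 3 in one place: 3,4-dichlorophenyl in place of 2,5-dimethylphenyl on an aromatic nitrogen. The measured steps that bear on this change are the swaps of the aryl group on the same aromatic nitrogen between compounds 1, 2 and 3, and none of them produced a readable number. There is thus no basis for expecting a step beyond the scatter in this assay in either direction. Compound 4 is accordingly expected to give about 50000 nM, in a range from 20000 nM to 100000 nM, most likely again as a limit rather than a number. The implied step, a number no higher from compound 3 to compound 4 (the limit leaves the size open), is expected to lie within the scatter.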

Compound 4, half-maximal inhibitory concentration: > 50000 nM
Compound 4: no number, only a limit; the forecaster's own chance of this, stated with the estimate: 85%; the middle value lies on the limit itself.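

In this assay compound 4 also gives only a limit, > 50000 nM. The steps linking it to compound 1, compound 2 and compound 3 therefore cannot be read, and the series remains at a single mark: the limit of > 50000 nM in this assay, at which 4 of the 4 values shown sit.

The compounds shown leave open whether any aryl group on this aromatic nitrogen, or any change elsewhere on the shared core, would give a readable number in this assay.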